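Lengthening a Side Chain: From Compound 2 to Compound 3

The compounds below may be only part of what the source reports. "The series", "measured", "known", "first", "only" and "open" are said of these compounds alone.

Compound 1 `CCCCCCCOc1ccc(CCC(N)(CO)CO)cc1` and compound 2 `CCCCCCCOc1ccc(CCC(N)(CC)CO)cc1` share one core and differ in a single group. In a functional assay on the whole organism (spleen, spleen) with Rattus norvegicus as the target (a higher number here means that more compound is needed for the effect, a lower number that less compound is needed), compound 1 gives 0.049 mg/kg, and compound 2 gives 0.059 mg/kg. The step between them, a 1.2-fold higher number from compound 1 to compound 2 (0.08 log units; within the scatter), shows that this swap hardly moved the number. Compound 2 therefore stands alongside compound 1; the two numbers cannot be told apart within the scatter.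

Compound 3 `CCCCCCCOc1ccc(CC[C@@](N)(CO)CCC)cc1` has not yet been measured. It differs from compound 2 by a group of 7 heavy atoms (5 carbon, 1 nitrogen, 1 oxygen; no ring) in place of a group of 6 heavy atoms (4 carbon, 1 nitrogen, 1 oxygen; no ring), on a saturated chain carbon, two bonds along the chain from an aromatic carbon. Among the compounds with values here, the only measured step touching this part of the molecule is a 1.2-fold higher number from compound 1 to compound 2 (0.08 log units; within the scatter), which stayed within the scatter, so a similarly small step is expected here, with no direction beyond the scatter. The expected result for compound 3 in this assay is 0.06 mg/kg, with a range from 0.025 mg/kg to 0.15 mg/kg. The change this estimate implies is expected to be a 1.0-fold higher number from compound 2 to compound 3 (0.01 log units; within the scatter).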

Compound 3, dose for 50% inhibition: 0.63 mg/kg
Compound 3: the middle estimate sits 11-fold (1.02 log units) below what was measured, and the stated range ends below it.
By their numbers in this assay, from the lowest: compounds 1 and 2 (each within the scatter of the next); then compound 3.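

This position proves sensitive in this assay: a group of 7 heavy atoms in place of a group of 6 heavy atoms gives an 11-fold higher number from compound 2 to compound 3 (1.03 log units; beyond the scatter), even though the earlier swap in this part of the molecule stayed within the scatter. The comparison with the other earlier compound agrees, at a 13-fold higher number from compound 1 to compound 3 (1.11 log units; beyond the scatter), so compound 3 needs more compound for the effect than either earlier compound, and a small change in this side chain can clearly matter. Nothing available here explains why the number rose.

The entering group also carries a defined stereocentre, so these compounds cannot separate the effect of the longer chain from that of the spatial arrangement at this carbon. As far as these compounds go, whether the mirror-image form of compound 3 would behave differently remains open, as does the result of a longer chain such as butyl at this position.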